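A few compounds are considered here, and "the series" means these few. Any claim that something is new, unique, unknown or untested is made for them only; others in the source may bear on it.

Two compounds measured in an assay on membranes from CHO-K1 cells for displacement of a labelled ligand from 5-hydroxytryptamine receptor 7 (Homo sapiens), read by scintillation counting (on this read-out higher numbers stand for weaker inhibition and lower numbers for stronger inhibition), share the same core and differ only in the aromatic ring attached to an amine nitrogen in a ring. Compound 1 `COc1cc2ncnc(N3CCC(CN4CCN(c5ccccc5O)CC4)C3)c2cc1OC` carries a 2-hydroxyphenyl there and in this assay compound 1 gives 661 nM. Compound 2 `COc1cc2ncnc(N3CCC(CN4CCN(c5ccccn5)CC4)C3)c2cc1OC` carries a pyridin-2-yl instead, and in this assay compound 2 gives 282 nM. That swap produced a 2.3-fold lower number from compound 1 to compound 2 (0.37 log units; beyond the scatter). For the measured compounds named here, compound 2 thus stands with the lowest of the two numbers, with compound 1 the only neighbour.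

Compound 3 `COc1cc2ncnc(N3CCC(CN4CCN(c5ncccn5)CC4)C3)c2cc1OC` is not yet measured. It differs from compound 2 in one place: pyrimidin-2-yl in place of pyridin-2-yl on an amine nitrogen in a ring. Going by the values given here, the only measured step at this position is the one from compound 1 to compound 2, and it was modest. A second nitrogen entering the aromatic ring is a smaller alteration than that earlier swap, so no step beyond the scatter is expected in this assay from compound 2 to compound 3, with a 1.1-fold higher number from compound 2 to compound 3 (0.05 log units; within the scatter) as the estimated change. Compound 3 is therefore expected to give about 320 nM in this assay, most likely between 120 nM and 850 nM.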

Compound 3, inhibition constant: > 1000 nM
Compound 3 gave a limit, no number (the forecaster's own chance of this, stated with the estimate: 3%); middle value at least 3.1-fold (0.49 log units) from the limit.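

In this assay, this position proves sensitive to a single atom: the ring stays six-membered and aromatic with the same heavy-atom count, yet pyrimidin-2-yl in place of pyridin-2-yl gives an at least 3.5-fold higher number from compound 2 to compound 3 (0.54 log units; beyond the scatter). The earlier step swapped a whole substituted ring, whereas this one shows that changing one ring carbon to a nitrogen can matter as much. Against the 2-hydroxyphenyl group, pyrimidin-2-yl gives an at least 1.5-fold higher number from compound 1 to compound 3 (0.17 log units; that floor lies within the scatter), so pyridin-2-yl holds the lowest number of the three, while the order of the other two groups remains unsettled.

The size of the loss also remains unknown, and so does the reason the second ring nitrogen costs binding, since compound 3 stands at a limit of the assay and not at a number: the limit of > 1000 nM in this assay, at which 1 of the 3 values shown sits.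

A plain phenyl or a cyclohexyl group on the same amine nitrogen would show whether the ring nitrogen of pyridin-2-yl contributes anything at all, or whether any simple ring there performs about as well.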